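A Dimethylamino Group Added to a Lipophilic Dienone

The source may report more compounds than this note shows. Statements on the series, on what has been measured and on what is new or still open speak of the compounds shown alone.

Among the compounds with values here, compound 1 `O=C1/C(=C/c2ccccc2)CCC/C1=C\c1cccc([N+](=O)[O-])c1` is one of two compounds measured so far. In a physicochemical assay for lipophilicity (a higher number here means a more lipophilic compound, a lower number a more polar compound), compound 1 gives 5.06. Within the data shown here, compound 2 `O=C1/C(=C/c2ccc(F)cc2)CCC/C1=C\c1ccccc1[N+](=O)[O-]` gives 4.86 in this assay, a number that sits within the scatter of the one for compound 1, so the two cannot be separated on this measurement. Compound 3 `CN(C)c1ccc(/C=C2\CCC/C(=C\c3cccc([N+](=O)[O-])c3)C2=O)cc1` has not yet been measured. Compared with compound 1, the change is dimethylamino in place of hydrogen on an aromatic carbon. Among the measured compounds shown here, no step between measured compounds that differ in one place is known, so no measured step can guide the expectation. A small rise is expected from the step of a number 0.24 log units higher from compound 1 to compound 3 (within the scatter) in this assay, about the size of the scatter or slightly beyond it. For compound 3 the estimate in this assay is 5.3, with a range from 4.9 to 5.7.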

Compound 3, partition coefficient: 5.06
Beside the measured number, compound 3's estimate is 0.24 log units above it; the measured number falls inside the stated range.
By their numbers in this assay, from the lowest: compounds 2, 1 and 3 (each within the scatter of the next).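

In this assay, dimethylamino in place of hydrogen on an aromatic carbon, para to a large group, gives no change at the digits printed from compound 1 to compound 3 (within the scatter), so this measurement does not separate the two compounds. Within the data shown here, the earlier compounds offered no step between compounds that differ in one place; this is the first such step, and it describes only the change from phenyl to 4-(dimethylamino)phenyl on the core of compound 1. No measurement shown here explains this result.

As far as these compounds go, whether a carboxylic acid or a longer amine chain at the same position would give a step beyond the scatter remains open. Also open, from the compounds shown here alone, is whether dimethylamino would give a similar step on the core of compound 2, where the other ring carries fluorine.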